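The source may hold more compounds than are shown below. What is called first, only, known or untested is meant among the compounds shown, and "the series" means these compounds.

Measured compounds:
Compound 1, `Cc1nc(SCC(=O)Nc2nc(-c3ccc(Cl)cc3)cs2)n(Nc2ccccc2)c1C`: 21600 nM
Compound 2, `Cc1ccc(Nn2c(SCC(=O)Nc3nc(-c4ccccc4)cs3)nc(C)c2C)cc1`: > 100000 nM

Within the data shown here, in a functional assay on Hs-578T cells (Homo sapiens) for antiproliferative activity, read by sulforhodamine B assay, with a stated time of 48 h (a higher number here means a weaker inhibitor of growth, a lower number a stronger inhibitor of growth), compound 1 gives 21600 nM, the only numerical value among the two compounds measured. Compound 2 is reported only as a limit in this assay, > 100000 nM; it reaches (the limit of > 100000 nM in this assay, at which 1 of the 2 values shown sits). Among the measured compounds shown here, no step between compounds that differ in a single place is available, so compound 2 shows only that its growth inhibition was not reached within the range tested.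

Compound 3, `COc1ccc(Nn2c(SCC(=O)Nc3nc(-c4ccc(Cl)cc4)cs3)nc(C)c2C)cc1`, has not been measured. It differs from compound 1 by methoxy in place of hydrogen on an aromatic carbon on the anilino ring. For the measured compounds named here, with no measured step to lean on, the expectation for the move from compound 1 to compound 3 is a modest weakening, close to the scatter, expressed as a 1.4-fold higher number from compound 1 to compound 3 (0.14 log units; within the scatter). Compound 3 is therefore estimated at 30000 nM in this assay, within a range from 8000 nM to 100000 nM.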

Compound 3, concentration for total growth inhibition: > 100000 nM
Compound 3: only a limit was reported (the forecaster's own chance of this, stated with the estimate: 30%); at least 3.3-fold (0.52 log units) between middle value and limit.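

In this assay compound 3 is reported only as a limit (> 100000 nM). Among these compounds, this gives the first step between compounds that differ in one place, an at least 4.6-fold higher number from compound 1 to compound 3 (0.66 log units; beyond the scatter) and so shows that the anilino ring of compound 1 does not take methoxy in place of hydrogen, para to a large group, without a weakening beyond the scatter. The true size of that weakening stays unknown, since only compound 1 carries a number here: the limit of > 100000 nM in this assay, at which 2 of the 3 values shown sit.

Going by these compounds, whether fluorine, a hydroxyl or an amine on the same carbon would keep the growth inhibition of compound 1 stays open. Equally open, on these data alone, is whether methoxy elsewhere on the anilino ring would act in the same way.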